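This account rests on a few compounds, and the source may have more. Where it says the series, first, only, none or still open, it means among the compounds named here.

Measured so far in an ADME assay on MDBK cells (Bos taurus) for cytotoxicity, read by MTT assay, with a stated time of 96 h; on this read-out higher numbers stand for lower toxicity in this test and lower numbers for higher toxicity in this test:
- compound 1 `C/C(=N\NC(N)=S)c1ccc2[nH]c(-c3ccccc3)nc2c1`: 32000 nM
- compound 2 `CC(=O)c1ccc2c(c1)nc(-c1ccccc1)n2C1CCCCC1`: > 100000 nM (a limit)
- compound 3 `C/C(=N\NC(N)=O)c1ccc2c(c1)nc(-c1ccccc1)n2C1CCCCC1`: > 100000 nM (a limit)

Compound 3 gives > 100000 nM, which is a limit of the assay and not a number. Compound 2 also sits at a limit, and the limit of > 100000 nM in this assay, at which 2 of the 3 values shown sit, is the main feature of the data so far. The next compound, compound 4 `C/C(=N\NC(N)=S)c1ccc2c(c1)nc(-c1ccccc1)n2C1CCCCC1`, differs from compound 3 by a group of 3 heavy atoms (1 carbon, 1 nitrogen, 1 sulfur; no ring) in place of a group of 3 heavy atoms (1 carbon, 1 nitrogen, 1 oxygen; no ring), on an amine nitrogen. Carbamoyl leaves, and the entering group carries sulfur where the old one carried oxygen.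

Among the measured compounds shown here, the only measured step, a step that the two limits leave unreadable from compound 2 to compound 3, gives no size to carry over. For the measured compounds named here, the sole numeric guide is compound 1, which gives 32000 nM and bears the same entering group on a different core. A step of an at least 2.0-fold lower number from compound 3 to compound 4 (0.30 log units; that floor lies within the scatter) is therefore expected in this assay, towards lower numbers and higher toxicity in this test, though its size is poorly defined. For compound 4 the estimate is 50000 nM, with an expected range from 15000 nM to 100000 nM.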

Compound 4, half-maximal cytotoxic concentration: 24000 nM
For compound 4 the middle estimate is 2.1-fold (0.32 log units) above the measured one; the measured number falls inside the stated range.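

In this assay, among the compounds shown here, the sulfur-bearing group in place of carbamoyl on the amine nitrogen gives an at least 4.1-fold lower number from compound 3 to compound 4 (0.61 log units; beyond the scatter), the first step with a readable direction, while the larger replacement on the aromatic carbon gives an at least 4.1-fold lower number from compound 2 to compound 4 (0.61 log units; beyond the scatter). Both steps give a floor and no exact size: the limit of > 100000 nM in this assay, at which 2 of the 4 values shown sit. With the sulfur-bearing group in place, cyclohexyl in place of hydrogen on the aromatic nitrogen gives a 1.3-fold lower number from compound 1 to compound 4 (0.12 log units; within the scatter), so this pair is not told apart in this test.

From the compounds shown here alone, whether carbamoyl on the core of compound 1 also reaches the limit stays open, so the sulfur exchange is read on one core only. Also open, going by these compounds, is how methyl in place of cyclohexyl, or an amine in place of the sulfur-bearing group, would read here.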